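Replacing Sulfamoyl with a Urea at the Assay Limit

The compounds below may be only part of what the source reports. "The series", "measured", "known", "first", "only" and "open" are said of these compounds alone.

Measured compounds in a functional assay on MDA-MB-231 cells (Homo sapiens) for antiproliferative activity, read by MTT assay, with a stated time of 72 h; a higher number here means a weaker inhibitor, a lower number a stronger inhibitor:
compound 1 `NS(=O)(=O)c1ccc(S(=O)(=O)Nc2cccc(-c3nc(-c4ccc(NC(=O)c5cccnc5)cc4Cl)no3)c2)cc1` gives > 10000 nM, a limit of the assay;
compound 2 `CC(=O)Nc1ccc(S(=O)(=O)Nc2cccc(-c3nc(-c4ccc(NC(=O)c5cccnc5)cc4)no3)c2)cc1` gives 5200 nM;
compound 3 `CC(=O)Nc1ccc(S(=O)(=O)Nc2cccc(-c3nc(-c4ccc(NC(=O)c5cccnc5)cc4C(F)(F)F)no3)c2)cc1` gives > 10000 nM, a limit of the assay.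

Compound 1 stands at the limit of > 10000 nM in this assay, at which 2 of the 3 values shown sit, so for compound 1 only a limit and no number is known. For the measured compounds named here, the one step measured between these compounds, an at least 1.9-fold higher number from compound 2 to compound 3 (0.28 log units; that floor lies within the scatter), concerns a change at a different place and does not bear on the step ahead. Compound 4 `CCNC(=O)Nc1ccc(S(=O)(=O)Nc2cccc(-c3nc(-c4ccc(NC(=O)c5cccnc5)cc4Cl)no3)c2)cc1` differs from compound 1 in one place: (ethylcarbamoyl)amino in place of sulfamoyl on an aromatic carbon. Going by the values given here, no measured pair shows the effect of this change, and compound 1 itself gives only a limit, so no step beyond the scatter in this assay can be read from these data in either direction. Compound 4 is therefore expected to remain near the limit, which the estimate a step that the limit leaves unreadable from compound 1 to compound 4 reflects. In this assay compound 4 is estimated at 12000 nM, between 3000 nM and 50000 nM.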

Compound 4, half-maximal inhibitory concentration: 3100 nM
Compound 4: the middle estimate sits 3.9-fold (0.59 log units) above what was measured; the measured number falls inside the stated range.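

In this assay, putting (ethylcarbamoyl)amino in place of sulfamoyl on the core of compound 1 produces a readable change at this position: an at least 3.2-fold lower number from compound 1 to compound 4 (0.50 log units; beyond the scatter). Compound 4 gives 3100 nM, a measured number, so this para-substituted site can respond to a change of group, and the response here is toward a stronger inhibitor. The true size of the step stays unknown, and only its floor can be read, because compound 1 gives a limit and not a number: the limit of > 10000 nM in this assay, at which 2 of the 4 values shown sit.

On these data alone, it remains open whether a longer chain in place of the ethyl of the (ethylcarbamoyl)amino group, or a plain amine at this place, would move the number further, and in which direction. Acetylamino in compound 2 cannot be compared with (ethylcarbamoyl)amino in compound 4, as those two compounds differ in more than one place.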